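Saturating the styryl linker in a sulfonamido-benzoic acid series

A few compounds are considered here, and "the series" means these few. Any claim that something is new, unique, unknown or untested is made for them only; others in the source may bear on it.

Measured compounds and their values in an assay on mitochondria (strain BALB/c) for inhibition of glycerol-3-phosphate acyltransferase 1, mitochondrial (Mus musculus), read by scintillation counting, with a stated time of 10 min; a higher number here means a weaker inhibitor, a lower number a stronger inhibitor:
Compound 1, `CCCCCCCCS(=O)(=O)Nc1cc(-c2ccc(CCCC)cc2)ccc1C(=O)O`, gives 15700 nM.
Compound 2, `CCCCCCCCS(=O)(=O)Nc1cc(-c2ccccc2F)ccc1C(=O)O`, gives 47200 nM.
Compound 3, `CCCCCCCCS(=O)(=O)Nc1cc(/C=C/c2ccccc2)ccc1C(=O)O`, gives 38000 nM.

Compound 3 stands second highest of the three numbers in this assay. Its nearest neighbour is compound 2, whose value lies within the scatter of compound 3, as the step of a 1.2-fold lower number from compound 2 to compound 3 (0.09 log units; within the scatter) shows. Going by the values given here, the step of a 2.4-fold higher number from compound 1 to compound 3 (0.38 log units; beyond the scatter) is the only one from compound 3 that lies beyond the scatter.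

Compound 4, `CCCCCCCCS(=O)(=O)Nc1cc(CCc2ccccc2)ccc1C(=O)O`, has not yet been measured in this assay. It differs from compound 3 in one place: phenethyl in place of 2-phenylethenyl on an aromatic carbon. Among the compounds with values here, no measured step changes this linker while keeping the phenyl, so no step bears directly on the change. The two steps that alter the group on this aromatic carbon, a 3.0-fold higher number from compound 1 to compound 2 (0.48 log units; beyond the scatter) and a 2.4-fold higher number from compound 1 to compound 3 (0.38 log units; beyond the scatter), were both modest, and the step of a 1.2-fold lower number from compound 2 to compound 3 (0.09 log units; within the scatter) was within the scatter.

The expected step of a 1.1-fold higher number from compound 3 to compound 4 (0.02 log units; within the scatter) is therefore small, in no definite direction. For compound 4 the estimate in this assay is 40000 nM, with a range from 15000 nM to 100000 nM.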

Compound 4, half-maximal inhibitory concentration: 37500 nM
For compound 4 the middle estimate is 1.1-fold (0.03 log units) above the measured one; measured number inside the range.
By their numbers in this assay, from the lowest: compound 1; then compounds 4, 3 and 2 (each within the scatter of the next).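

In this assay, going by these compounds alone, removing the one double bond outside the aromatic rings makes no difference beyond the scatter, a 1.0-fold lower number from compound 3 to compound 4 (0.01 log units; within the scatter), and this is the first step that changes the linker while keeping the phenyl. At this aromatic carbon, para to a carboxy group, the 2-phenylethenyl and phenethyl groups therefore cannot be told apart, and compound 4 also lies within the scatter of the 2-fluorophenyl compound, a 1.3-fold lower number from compound 2 to compound 4 (0.10 log units; within the scatter), while the 4-butylphenyl compound stays separate, a 2.4-fold higher number from compound 1 to compound 4 (0.38 log units; beyond the scatter), so that compound 1 alone stands beyond the scatter of the other three. No measurement at hand accounts for the double bond making so little difference.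

From the compounds shown here alone, whether the butyl chain of compound 1 would have the same effect on the phenethyl group, as a 4-butylphenethyl group, remains open, as does the effect of an amide or an ether oxygen in the linker. The sulfonamide chain and the carboxylic acid are the same in all four compounds, so these results say nothing about how a shorter chain or a tetrazole there would behave.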